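The source may hold more compounds than are shown below. What is called first, only, known or untested is meant among the compounds shown, and "the series" means these compounds.

Three compounds have been measured in a functional assay on HEK293 cells for agonist activity at D(4) dopamine receptor (Homo sapiens), read by FLIPR; a lower number here means that less compound is needed, a higher number that more compound is needed for the effect:

Compound 1, `Cc1ccc([N+](=O)[O-])cc1NC(=O)CN1CCC(c2cccc[n+]2[O-])CC1`, gives 134 nM.
Compound 2, `COc1cc(C(=O)NCN2CCC(c3cccc[n+]3[O-])CC2)ccc1Cl`, gives 159 nM.
Compound 3, `Cc1cccc(C(=O)NCN2CCC(c3nccs3)CC2)c1`, gives 9.8 nM.

Compound 1 stands second highest of the three numbers in this assay. Its nearest neighbour is compound 2, whose value lies within the usual scatter of repeated measurements, so the two cannot be told apart. Compound 3 is the furthest away, with a value that is beyond the scatter and clearly lower than that of compound 1.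

The account now turns from compound 1 to compound 4, `Cc1ccc(Cl)cc1NC(=O)CN1CCC(c2cccc[n+]2[O-])CC1`, which has not been measured in this assay. The two structures differ in one place: chloro in place of nitro on an aromatic carbon. Going by the values given here, no step between measured compounds involving this change is available, so what follows rests on compound 1 alone and on the size of the change.

For compound 4 the expected value in this assay is 100 nM, with a range from 30 nM to 400 nM. The expected step, a 1.3-fold lower number from compound 1 to compound 4 (0.13 log units; within the scatter), is small and most likely within the scatter, with no clear direction.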

Compound 4, half-maximal effective concentration: 126 nM
Estimate against measurement, compound 4: 1.3-fold (0.10 log units) below; the range from low to high includes it.
By their numbers in this assay, from the lowest: compound 3; then compounds 4, 1 and 2 (each within the scatter of the next).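

In this assay, going by these compounds alone, chloro in place of nitro on the aromatic carbon gives a 1.1-fold lower number from compound 1 to compound 4 (0.03 log units; within the scatter) and so provides the first step where only one place differs. At this position, meta to a large group and para to a methyl group, a single chlorine atom stands in for a nitro group of three heavy atoms with two hydrogen-bond acceptors, and the measurement cannot tell the two compounds apart. On the core of compound 1, then, neither the nitro group's hydrogen-bond acceptors nor its larger count of heavy atoms is needed to keep the value within the scatter, and nothing available explains why the two groups match.

Going by these compounds, what remains open is whether an amine, a carboxylic acid or a longer chain at this aromatic carbon would also stay within the scatter of chloro and nitro, or would instead mark a clear step in either direction. On these data alone, it is also open whether chloro and nitro would still match if the methyl group were replaced by another group, or if the same change were made on a different core.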